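The source may report more compounds than this note shows. Statements on the series, on what has been measured and on what is new or still open speak of the compounds shown alone.

Two ureas have so far been measured in an ADME assay on the whole organism with Oryza sativa as the target, tested at 10 uM; on this read-out higher numbers stand for a weaker effect at the one concentration tested and lower numbers for a stronger effect. Among the measured compounds shown here, compound 1 `Cc1ccccc1NC(=O)N[C@@H](C)c1ccccc1` gives 99% there, while compound 2 `C[C@H](NC(=O)Nc1ccccc1F)c1ccccc1` gives 65%, the lower of the two numbers; the one measured step, a number 34 percentage points lower from compound 1 to compound 2 (beyond the scatter), lies beyond the scatter. Compound 3 `C[C@H](NC(=O)Nc1ccccc1I)c1ccccc1` has not yet been measured. It differs from compound 2 by iodo in place of fluoro on an aromatic carbon. For the measured compounds named here, this change sits at the same place as the one measured step, but that step swapped a methyl for a fluoro, so it bears only loosely on exchanging one halogen for another, and no measured compound carries an iodo at all. In this assay a moderate step in either direction therefore cannot be excluded, and the estimate for compound 3 is 60%, within a range of 30% to 95%. That estimate means a number 5 percentage points lower from compound 2 to compound 3 (within the scatter), a step expected to stay close to the scatter.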

Compound 3, a percentage reported as activity, at one concentration (the size of the read-out at that concentration, not a potency): 98%
Beside the measured number, compound 3's estimate is 38 percentage points below it, outside the stated range (above it).
By their numbers in this assay, from the lowest: compound 2; then compounds 3 and 1 (each within the scatter of the next).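

With a number 33 percentage points higher from compound 2 to compound 3 (beyond the scatter) in this assay, it becomes clear that exchanging one halogen for another on this aromatic carbon can be a large change, and that fluoro and iodo need not read alike here. Iodo and methyl cannot be told apart at this place, with a number 1 percentage points lower from compound 1 to compound 3 (within the scatter) as their step, so among the three groups shown, fluoro alone stands apart, with the lower number. Nothing at hand explains this difference.

Going by these compounds, whether chloro or bromo on this carbon would read like fluoro, like iodo or somewhere in between remains open. So does the reading for a group such as methoxy or hydroxy at this place, which would show whether the low number belongs to fluoro alone.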